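Cyclopropyl to isopropyl on the piperidine amide carbonyl

This account rests on a few compounds, and the source may have more. Where it says the series, first, only, none or still open, it means among the compounds named here.

Measured compounds:
compound 1 `O=C(CC1CCN(C(=O)C2CC2)CC1)Nc1ccc(OC(F)(F)F)c(F)c1`, 5.11
compound 2 `O=C(Nc1ccc(C(F)(F)F)c(F)c1)NC1CCN(C(=O)C2CC2)CC1`, 3.94
compound 3 `CC(C)C(=O)N1CCC(NC(=O)Nc2ccc(C(F)(F)F)c(F)c2)CC1`, 4.4

In a physicochemical assay for lipophilicity, read by HPLC, with a stated time of 90 min, tested at 100 uM (a higher number here means a more lipophilic compound, a lower number a more polar compound), compound 1 gives 5.11, the highest of the three numbers; compound 3 gives 4.4 and compound 2 gives 3.94, both beyond the scatter below compound 1. The difference between the core of compound 1 and the core of compound 2 is not broken down here.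

Compound 2 and compound 3 differ by one change, (isopropyl in place of cyclopropyl on a carbonyl carbon), and in this assay it gave a number 0.46 log units higher from compound 2 to compound 3 (beyond the scatter).

Compound 4 `CC(C)C(=O)N1CCC(CC(=O)Nc2ccc(OC(F)(F)F)c(F)c2)CC1` is not yet measured. It differs from compound 1 by the same kind of change, (isopropyl in place of cyclopropyl on a carbonyl carbon), at the same place. For the measured compounds named here, the expected step from compound 1 to compound 4 in this assay is a number 0.44 log units higher from compound 1 to compound 4 (beyond the scatter), resting on compound 2 and compound 3, because a number 0.46 log units higher from compound 2 to compound 3 (beyond the scatter) is the only measured instance of this change. Compound 4 is therefore estimated at 5.55, with the range 5.2 to 5.9.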

Compound 4, partition coefficient: 5.81
Beside the measured number, compound 4's estimate is 0.26 log units below it; low and high end bracket the measured number.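

In this assay, isopropyl in place of cyclopropyl on a carbonyl carbon gave a number 0.70 log units higher from compound 1 to compound 4 (beyond the scatter), and on the other core it gave a number 0.46 log units higher from compound 2 to compound 3 (beyond the scatter), so the step has the same direction on both cores. These two pairs show that the direction carried from one core to the other here, but they do not establish a rule for other cores in the series or show what sets the size of the step. No measurement shown here accounts for the direction or size of either step.

The compounds shown leave open what a longer chain such as butyl, or an amine such as dimethylamino, would give on the same carbonyl carbon in this assay.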